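Fluorophenyl Position Swap in a Second Core

The compounds below may be only part of what the source reports. "The series", "measured", "known", "first", "only" and "open" are said of these compounds alone.

Compound 1 `COc1cc(/C=C2\CN(C)C/C(=C\c3ccccc3F)C2=O)cc(OC)c1OC` gives 3220 nM in a functional assay on HeLa cells (Homo sapiens) for cytotoxicity, read by MTT assay, with a stated time of 24 h; a lower number here means a stronger inhibitor, a higher number a weaker inhibitor. Compound 3 `COc1cc(/C=C2\CN(C)C/C(=C\c3ccc(F)cc3)C2=O)cc(OC)c1OC` gives 7250 nM in this assay; the difference is 4-fluorophenyl in place of 2-fluorophenyl on a double-bonded chain carbon bound to a double-bonded ring carbon, and it made a 2.3-fold higher number from compound 1 to compound 3 (0.35 log units; beyond the scatter). Compound 2 `CN1C/C(=C\c2cccc([N+](=O)[O-])c2)C(=O)/C(=C/c2ccccc2F)C1` gives 2340 nM in this assay; the difference between the core of compound 2 and the core of compound 1 is not broken down here. Compound 4 `CN1C/C(=C\c2ccc(F)cc2)C(=O)/C(=C/c2cccc([N+](=O)[O-])c2)C1` is not yet measured in this assay; it differs from compound 2 by 4-fluorophenyl in place of 2-fluorophenyl on a double-bonded chain carbon bound to a double-bonded ring carbon, the same change seen from compound 1 to compound 3, at the same place. Among the compounds with values here, the step from compound 2 to compound 4 is expected to be a 2.3-fold higher number from compound 2 to compound 4 (0.36 log units; beyond the scatter), resting on the single precedent a 2.3-fold higher number from compound 1 to compound 3 (0.35 log units; beyond the scatter); with one example, confidence is limited. Compound 4 is expected to give 5400 nM in this assay, with a plausible range from 2700 nM to 11000 nM.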

Compound 4, half-maximal inhibitory concentration: 6250 nM
Compound 4: middle estimate off by 1.2-fold (0.06 log units), on the low side, and the stated range covers the measured number.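

In this assay, 4-fluorophenyl in place of 2-fluorophenyl made a 2.7-fold higher number from compound 2 to compound 4 (0.43 log units; beyond the scatter) on the second core, so the change carried over between the two cores with the same direction and a similar size: the same change on two cores in this assay, a 2.3-fold higher number (0.35 log units; beyond the scatter) from compound 1 to compound 3 and a 2.7-fold higher number (0.43 log units; beyond the scatter) from compound 2 to compound 4, 1.2-fold (0.07 log units) apart, within the scatter of two such steps.

Within the data shown here, this rests on only two pairs of compounds, so it does not show that the step would hold on any further core. It also gives no reason for the step.

Still open, on these data alone, is whether a chlorophenyl or a pyridyl group at the same place would follow the fluorophenyl pair. The compounds shown also leave open how a group other than fluorine on that phenyl ring would compare on either core.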